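Substitution on the oxygen: from compound 3 to compound 4

The source may report more compounds than this note shows. Statements on the series, on what has been measured and on what is new or still open speak of the compounds shown alone.

Going by the values given here, in a functional assay on NCI-H460 cells (Homo sapiens) for cytotoxicity, read by sulforhodamine B assay, with a stated time of 3 days (on this read-out higher numbers stand for weaker inhibition and lower numbers for stronger inhibition), compound 1 (`OCc1cn(Cc2ccc(Cl)cc2)c2ccccc12`) gives 16 nM, compound 2 (`CC(O)c1cn(Cc2ccc(Cl)cc2)c2ccccc12`) gives 25100 nM and compound 3 (`COCc1cn(Cc2ccc(Cl)cc2)c2ccccc12`) stands between them at 1990 nM on the numbers so far. Compound 4 (`O=C(NC1CCCCC1)OCc1cn(Cc2ccc(Cl)cc2)c2ccccc12`) has cyclohexylcarbamoyl in place of methyl on an oxygen on a saturated carbon. Among the compounds with values here, the one measured change on that oxygen is a large rise in the number (a 120-fold higher number from compound 1 to compound 3 (2.09 log units; beyond the scatter)). A methyl on the neighbouring chain carbon gave a larger rise (a 1600-fold higher number from compound 1 to compound 2 (3.20 log units; beyond the scatter)). Within the data shown here, no measured compound carries cyclohexylcarbamoyl, so the range stays wide. Because compound 3 gives 1990 nM without the hydrogen on that oxygen and compound 4 also lacks that hydrogen, no step beyond the scatter is expected (a 1.3-fold lower number from compound 3 to compound 4 (0.12 log units; within the scatter)) in this assay on present data. Compound 4 is estimated at 1500 nM (expected range 100 nM to 15000 nM).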

Compound 4, half-maximal inhibitory concentration: 20 nM
Compound 4: middle estimate off by 75-fold (1.88 log units), on the high side; measured number outside the range, below it.
By their numbers in this assay, from the lowest: compounds 1 and 4 (each within the scatter of the next); then compound 3; then compound 2.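

In this assay the oxygen on a saturated carbon can carry cyclohexylcarbamoyl without the loss seen with methyl: replacing methyl reverses that loss (a 100-fold lower number from compound 3 to compound 4 (2.00 log units; beyond the scatter)), and replacing hydrogen leaves a step within the scatter (a 1.3-fold higher number from compound 1 to compound 4 (0.10 log units; within the scatter)). Absence of the hydrogen on that oxygen therefore does not by itself set the number; the group that enters matters. No evidence on the cause is at hand. Still open, from the compounds shown here alone, is whether an acetyl or a phenylcarbamoyl group on that oxygen follows cyclohexylcarbamoyl or methyl.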